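The source may report more compounds than this note shows. Statements on the series, on what has been measured and on what is new or still open speak of the compounds shown alone.

Measured so far in an assay on isolated protein for agonist activity at Bile acid receptor (Homo sapiens), read by AlphaScreen, with a stated time of 30 min; a lower number here means a smaller maximal response, a higher number a larger maximal response:
compound 1 `CCc1ccccc1-n1nc(C)c2c1NC(=O)[C@H](C)S[C@@H]2c1ccc(Oc2ccccc2)cc1` gives 190%
compound 2 `CCCc1ccccc1-n1nc(C)c2c1NC(=O)[C@H](C)S[C@@H]2c1ccc(Oc2ccccc2)cc1` gives 240%
compound 3 `Cc1nn(-c2ccccc2C(C)C)c2c1[C@@H](c1ccc(Oc3ccccc3)cc1)S[C@@H](C)C(=O)N2` gives 174%

Compound 3 stands lowest of the three numbers; its nearest neighbour is compound 1 and its furthest is compound 2, and both gaps lie beyond the scatter. Compound 4 `Cc1cccc(-n2nc(C)c3c2NC(=O)[C@H](C)S[C@@H]3c2ccc(Oc3ccccc3)cc2)c1` is not yet measured. The change from compound 3 is 3-methylphenyl in place of 2-isopropylphenyl on an aromatic nitrogen.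

All three measured steps alter the group carried on the phenyl that sits on the aromatic nitrogen, so all of them bear on this step, though none produces a 3-methylphenyl. a number 50 percentage points higher from compound 1 to compound 2 (beyond the scatter). a number 16 percentage points lower from compound 1 to compound 3 (beyond the scatter). a number 66 percentage points lower from compound 2 to compound 3 (beyond the scatter). Every alteration of this phenyl so far has shifted the maximal response beyond the scatter, in one direction or the other, so a step beyond the scatter is expected here as well, with its direction the open question. Compound 1 gives 190% and stands above compound 3 beyond the scatter, so a modest rise is taken as the more likely outcome, with a wide range. Compound 4 is expected to give 195%, between 150% and 245%, which amounts to an expected step of a number 21 percentage points higher from compound 3 to compound 4 (beyond the scatter).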

Compound 4, largest response reached (reported as efficacy), in percent of the reference or control that the assay uses: 22%
Beside the measured number, compound 4's estimate is 173 percentage points above it; measured number outside the range, below it.
By their numbers in this assay, from the lowest: compound 4; then compound 3; then compound 1; then compound 2.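

In this assay, the move to 3-methylphenyl on the aromatic nitrogen gives a number 152 percentage points lower from compound 3 to compound 4 (beyond the scatter), with a number 218 percentage points lower from compound 2 to compound 4 (beyond the scatter) and a number 168 percentage points lower from compound 1 to compound 4 (beyond the scatter), each larger than the biggest earlier step at this position, a number 66 percentage points lower from compound 2 to compound 3 (beyond the scatter). The 2-ethylphenyl, 2-propylphenyl and 2-isopropylphenyl compounds showed only shifts among high maximal responses, with compound 3 lowest of them at 174%, whereas compound 4 at 22% shows that a change at this position alone, on an otherwise unchanged core, can remove most of that response. No measurement among the compounds shown accounts for this drop.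

Compound 4 differs from the others both in the alkyl group and in where it stands on the phenyl, so the compounds shown cannot separate the contribution of the shorter group from that of its placement. A 2-methylphenyl, a 3-propylphenyl or an unsubstituted phenyl on the same nitrogen would be needed to tell these apart, and the compounds shown do not say how any of them would behave.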